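The compounds below may be only part of what the source reports. "The series", "measured", "known", "first", "only" and "open" are said of these compounds alone.

Compound 1 `O=C(Nc1cccc(-c2cccc(F)c2)c1)C(Cl)Cl` is the starting point here. In a functional assay on KB 3-1 cells (Homo sapiens) for cytotoxicity, read by MTT assay, with a stated time of 68 h (a higher number here means a weaker inhibitor, a lower number a stronger inhibitor), compound 1 gives > 50000 nM, which is a limit of the assay rather than a measured number. Compound 1 therefore sits at the limit of > 50000 nM in this assay, at which 2 of the 3 values shown sit, together with one other compound. Compound 2 `O=C(Nc1cccc(-c2ccc(-c3ccccc3)cc2)c1)C(Cl)Cl` gives > 50000 nM, also a limit. Among the measured compounds shown here, compound 3 `COc1ccccc1-c1cc(NC(=O)C(Cl)Cl)cc(-c2ccccc2OC)c1` gives > 30000 nM, again a limit, so no compound so far shows a measurable number in this assay. Compound 4 `O=C(Nc1cccc(-c2cccc(C(F)(F)F)c2)c1)C(Cl)Cl` differs from compound 1 by a single change (trifluoromethyl in place of fluoro on an aromatic carbon). For the measured compounds named here, with no measured step to lean on and every value so far a limit, the expected step is a number no higher from compound 1 to compound 4 (the limit leaves the size open), none beyond the scatter. Compound 4 is expected to give about 50000 nM, between 20000 nM and 120000 nM, and most likely to be reported as a limit once more.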

Compound 4, half-maximal inhibitory concentration: > 50000 nM
Compound 4 ended at the assay's limit; the forecaster's own chance of this, stated with the estimate: 80%; the middle value lies on the limit itself.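

Compound 1 and compound 4 both stop at a limit in this assay, not at a measured number, so no step can be read between them. The compounds shown leave open how trifluoromethyl or fluoro affects cytotoxicity on this core.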